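The source may hold more compounds than are shown below. What is called first, only, known or untested is meant among the compounds shown, and "the series" means these compounds.

Measured so far:
compound 1 `CCCCc1ccc(S(=O)(=O)NCCCCCCNCc2ccc(Br)cc2)cc1` — 5700 nM
compound 2 `CC(C)(C)c1ccc(CNCCCNS(=O)(=O)c2cc(C(F)(F)F)cc(C(F)(F)F)c2)cc1` — 2300 nM
compound 3 `O=S(=O)(NCCCNCc1ccc(-c2ccccc2)cc1)c1cc(C(F)(F)F)cc(C(F)(F)F)c1` — 2400 nM

In a functional assay on MIA PaCa-2 cells (Homo sapiens) for inhibition, read by MTT assay, with a stated time of 72 h (on this read-out lower numbers stand for stronger inhibition of growth and higher numbers for weaker inhibition of growth), compound 1 gives the highest number of the three, while compound 2 and compound 3 sit close together, the step of a 1.0-fold higher number from compound 2 to compound 3 (0.02 log units; within the scatter) being within the scatter. Compound 4 `Cc1ccc(S(=O)(=O)NCCCCCCNCc2ccc(Br)cc2)cc1` keeps the core of compound 1 and differs only by hydrogen in place of propyl on a saturated chain carbon bound to an aromatic carbon. Among the measured compounds shown here, none of the measured steps alters this part of the molecule, so the only comparison in hand, the phenyl-for-tert-butyl step on the other aryl, offers no direct guide. With no evidence for a shift either way, compound 4 is expected to land near compound 1 in this assay, the step of a 1.2-fold higher number from compound 1 to compound 4 (0.09 log units; within the scatter) being an estimate, with the value expected at 7000 nM and a range from 3000 nM to 20000 nM.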

Compound 4, concentration for 50% growth inhibition: 12300 nM
For compound 4 the middle estimate is 1.8-fold (0.24 log units) below the measured one; the measured number falls inside the stated range.
By their numbers in this assay, from the lowest: compounds 2 and 3 (each within the scatter of the next); then compound 1; then compound 4.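

In this assay the change from butyl to methyl, on a saturated chain carbon bound to an aromatic carbon, gives a 2.2-fold higher number from compound 1 to compound 4 (0.33 log units; beyond the scatter) and so shows that this position does count: the shorter chain goes with weaker inhibition of growth. The earlier step concerned another place and could not show this. No measurement here explains the shift. Still open, on these data alone, is whether growth inhibition follows chain length, as ethyl or a longer chain such as hexyl could show. An amine or a carboxylic acid at this place is also untested among the compounds shown.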